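This account rests on a few compounds, and the source may have more. Where it says the series, first, only, none or still open, it means among the compounds named here.

For the measured compounds named here, in an assay on HEK293 cells for agonist activity at transient receptor potential cation channel subfamily M member 8 (Homo sapiens), read by fluorescence and calcium flux, with a stated time of 15 min (a higher number here means that more compound is needed for the effect, a lower number that less compound is needed), compound 1 `CCN(Cc1cccs1)C(=O)COc1ccc(C)cc1` gives 8 nM and compound 2 `CCN(Cc1cccs1)C(=O)COc1ccc(C(F)(F)F)cc1` gives 236 nM; compound 2 therefore stands at the highest of the two numbers so far, with compound 1 its only neighbour. Going by the values given here, the one measured step, a 30-fold higher number from compound 1 to compound 2 (1.47 log units; beyond the scatter), is the sole comparison available. Compound 3 `CCc1ccc(OCC(=O)N(CC)Cc2cccs2)cc1` differs from compound 2 by ethyl in place of trifluoromethyl on an aromatic carbon. Ethyl has not itself been measured, so the prior step bears on this one only partly. Given the size of a 30-fold higher number from compound 1 to compound 2 (1.47 log units; beyond the scatter), compound 3 is expected to give a lower number, the estimated step being a 9.4-fold lower number from compound 2 to compound 3 (0.97 log units; beyond the scatter). The estimate for compound 3 in this assay is 25 nM, within 8 nM to 80 nM.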

Compound 3, half-maximal effective concentration: 67 nM
Compound 3: middle estimate off by 2.7-fold (0.43 log units), on the low side, and the stated range covers the measured number.
By their numbers in this assay, from the lowest: compound 1; then compound 3; then compound 2.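

In this assay, the aromatic carbon para to a large group now carries three compared groups, and ethyl recovers only part of the trifluoromethyl shift: a 3.5-fold lower number from compound 2 to compound 3 (0.55 log units; beyond the scatter). Ethyl still falls short of methyl, with an 8.4-fold higher number from compound 1 to compound 3 (0.92 log units; beyond the scatter), so one added carbon on the methyl group already moves the number beyond the scatter. No measurement here accounts for this order.

Going by these compounds, whether a longer chain, a methoxy group or an amine at this position would follow the same trend remains open. On these data alone, the effect of these groups with the rest of the core changed also remains open.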